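A few compounds are considered here, and "the series" means these few. Any claim that something is new, unique, unknown or untested is made for them only; others in the source may bear on it.

Two compounds of a shared core carry a trimethoxyphenyl group linked through a double bond to a brominated lactam ring. Compound 1 `COc1cc(/C=C/C(=O)N2CCC=C(Br)C2=O)cc(OC)c1OC` has only hydrogen on the double-bonded chain carbon next to the carbonyl, and in a functional assay on HCT-116 cells (Homo sapiens) for cytotoxicity, read by MTT assay, with a stated time of 72 h (on this read-out higher numbers stand for weaker inhibition and lower numbers for stronger inhibition), compound 1 gives 7120 nM. Compound 2 `CC/C(=C\c1cc(OC)c(OC)c(OC)c1)C(=O)N1CCC=C(Br)C1=O` carries an ethyl group at that position, and in this assay compound 2 gives 3020 nM. Of these two numbers compound 2 stands at the lower one; the gap from compound 1 lies beyond the usual scatter of repeated measurements, so compound 2 is the stronger inhibitor of the pair.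

Compound 3 `CCC/C(=C\c1cc(OC)c(OC)c(OC)c1)C(=O)N1CCC=C(Br)C1=O` is the next step along this line: methyl in place of hydrogen on a saturated chain carbon, two bonds along the chain from a double-bonded chain carbon. The change is small, adds no ring, no donor and no acceptor, and simply lengthens the saturated chain on the same carbon. For the measured compounds named here, since no pair of measured compounds shows the effect of such a lengthening, the expected step is modest, with a 1.2-fold lower number from compound 2 to compound 3 (0.08 log units; within the scatter) expected to lie within or close to the scatter. Compound 3 is therefore estimated at 2500 nM in this assay, with a range from 1000 nM to 6500 nM.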

Compound 3, half-maximal inhibitory concentration: 2140 nM
The estimate for compound 3 lay 1.2-fold (0.07 log units) above the measured number; low and high end bracket the measured number.
By their numbers in this assay, from the lowest: compounds 3 and 2 (each within the scatter of the next); then compound 1.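

Swapping ethyl for propyl on this chain gives the first direct reading of what lengthening the saturated chain does, and in this assay the result is a 1.4-fold lower number from compound 2 to compound 3 (0.15 log units; within the scatter) in this comparison. The numbers of compound 2 and compound 3 therefore cannot be told apart, so at this place on the chain the added methyl is tolerated, and this assay shows no measurable difference between the ethyl and propyl chains. The data shown offer no independent measurement that could explain how this chain acts on the cells.

Going by these compounds, whether the same tolerance holds for a longer chain such as butyl or hexyl, for a branched chain such as isopropyl, or for a chain ending in an amine or a carboxylic acid remains open. On these data alone, it is also open how far the chain can grow before the number in this assay clearly moves in either direction, since a single step that lies within the usual scatter cannot show a trend.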